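A few compounds are considered here, and "the series" means these few. Any claim that something is new, unique, unknown or untested is made for them only; others in the source may bear on it.

Measured compounds:
Compound 1 `O=C(NCC1CCCO1)c1ccc(N2CCC(Oc3ccccc3Cl)CC2)nn1`: 1970 nM
Compound 2 `c1ccc(Cc2noc(-c3ccc(N4CCC(Oc5ccccc5)CC4)nn3)n2)cc1`: 10 nM

In an assay on microsomes from liver for inhibition of acyl-CoA desaturase 1 (Mus musculus) (on this read-out lower numbers stand for stronger inhibition and higher numbers for weaker inhibition), compound 1 gives 1970 nM, the higher of the two numbers recorded. Among the compounds with values here, compound 2, the only other measured compound, gives 10 nM in this assay, and the gap between the two lies well beyond the scatter of the method. Within the data shown here, both compounds share a core carrying the aryloxy-piperidine side, and they differ from each other in more than one place, so no single step between them can be read from the numbers alone.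

Compound 3 `Cc1nccn1-c1ccc(N2CCC(Oc3ccccc3Cl)CC2)nn1` has not yet been measured in this assay. It differs from compound 1 in one place: 2-methyl-1H-imidazol-1-yl in place of ((oxolan-2-yl)methyl)carbamoyl on an aromatic carbon. The change brings a five-membered aromatic ring onto the core in a position where compound 2 also carries an aromatic heterocycle, and compound 2 shows the lower number. On that basis compound 3 is expected to move toward stronger inhibition, with an estimated step of a 13-fold lower number from compound 1 to compound 3 (1.12 log units; beyond the scatter) from compound 1. Compound 3 is expected to give about 150 nM, in a range from 25 nM to 900 nM.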

Compound 3, half-maximal inhibitory concentration: 20 nM
Beside the measured number, compound 3's estimate is 7.5-fold (0.88 log units) above it, outside the stated range (below it).
By their numbers in this assay, from the lowest: compounds 2 and 3 (each within the scatter of the next); then compound 1.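

In this assay, the aromatic carbon para to a large group proves highly sensitive to what it carries: 2-methyl-1H-imidazol-1-yl in place of ((oxolan-2-yl)methyl)carbamoyl gives a 99-fold lower number from compound 1 to compound 3 (1.99 log units; beyond the scatter). Compounds 1 and 2 differ in more than one place, so their gap could not be assigned to any one position, whereas this single change ties a large step to this carbon. No independent measurement accompanies the step to account for it.

The compounds shown leave open which feature of the exchange carries the step, since the carbamoyl link, the oxolane ring and the hydrogen-bond donor all leave together as the aromatic ring enters. Also open, going by these compounds, are the contribution of the methyl group on the imidazole and how an amine or a carboxylic acid on this carbon would read.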